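Solubility along the ortho substituent of the benzylamine

This account rests on a few compounds, and the source may have more. Where it says the series, first, only, none or still open, it means among the compounds named here.

Compound 3 `O=[N+]([O-])c1cn2c(n1)OC[C@@H](NCc1ccc(OC(F)(F)F)cc1F)C2` gives 72 ug/mL in a physicochemical assay for solubility, at pH 6.8 (on this read-out lower numbers stand for lower solubility and higher numbers for higher solubility), the highest of the two numbers recorded for the series. Compound 1 `O=[N+]([O-])c1cn2c(n1)OC[C@@H](NCc1ccc(OC(F)(F)F)cc1Oc1ccccc1)C2`, in which the same position carries a phenoxy group, gives 3 ug/mL in this assay. Compound 2 `CCCN(Cc1ccc(OC(F)(F)F)cc1)[C@@H]1COc2nc([N+](=O)[O-])cn2C1` reports only a limit in this assay, < 2 ug/mL. Within the data shown here, the one measured step that bears on the present change is a 24-fold higher number from compound 1 to compound 3 (1.38 log units; beyond the scatter), a large move on this read-out.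

Compound 4 `O=[N+]([O-])c1cn2c(n1)OC[C@@H](NCc1ccc(OC(F)(F)F)cc1OCC1CC1)C2` differs from compound 3 by cyclopropylmethoxy in place of fluoro on an aromatic carbon. Among the measured compounds shown here, since the only step of this kind seen, a 24-fold higher number from compound 1 to compound 3 (1.38 log units; beyond the scatter), was a large gain on going from a large ortho group to fluoro, a large loss is expected in this assay on going back to a large ortho group. Compound 4 is therefore expected to give 5 ug/mL, with a range of 1.5 ug/mL to 20 ug/mL. The expected step is a 14-fold lower number from compound 3 to compound 4 (1.16 log units; beyond the scatter). There is a real chance that the result falls at the limit of < 2 ug/mL in this assay, at which 1 of the 3 values shown sits, and no number is reported.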

Compound 4, solubility: 6 ug/mL
Compound 4: middle estimate off by 1.2-fold (0.08 log units), on the low side; measured number inside the range.
By their numbers in this assay, from the lowest: compounds 1 and 4 (each within the scatter of the next); then compound 3. At a limit, below all of these: compound 2.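

A second large ether at this position gives the same result in this assay: a 12-fold lower number from compound 3 to compound 4 (1.08 log units; beyond the scatter), so the low number is not peculiar to phenoxy. Cyclopropylmethyl and phenyl on the oxygen cannot be told apart on this read-out, with a 2.0-fold higher number from compound 1 to compound 4 (0.30 log units; within the scatter), so the non-aromatic three-membered ring offers no gain over the phenyl ring here. Compound 2 remains the only compound at a limit, which is not a number: the limit of < 2 ug/mL in this assay, at which 1 of the 4 values shown sits.

Among the compounds shown, fluoro is the only group at this position that is not an ether, so the data do not separate the size of the group from the ether oxygen; methoxy would bear on this. Also open, from the compounds shown here alone, is whether an amine or a carboxylic acid at the end of the chain on the oxygen would bring the number back towards that of compound 3, 72 ug/mL.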